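This account rests on a few compounds, and the source may have more. Where it says the series, first, only, none or still open, it means among the compounds named here.

Measured in a functional assay on LoVo cells (Homo sapiens) for antiproliferative activity, read by MTT assay, with a stated time of 72 h; on this read-out lower numbers stand for stronger inhibition and higher numbers for weaker inhibition:
- compound 1 `Cc1noc(C)c1-c1nn(Cc2ccc(C(=O)NC3CC3)cc2)c(=O)c2ccccc12` gives > 100000 nM
- compound 2 `Cn1cc(-c2nn(Cc3ccc(C(=O)NC4CCCC4)cc3)c(=O)c3ccccc23)cn1` gives 23700 nM

Compound 1 yields only a limit, not a number, and stands at the limit of > 100000 nM in this assay, at which 1 of the 2 values shown sits. Compound 3 `Cc1noc(C)c1-c1nn(Cc2ccc(C(=O)NC3CC(C)(C)N([O])C(C)(C)C3)cc2)c(=O)c2ccccc12` keeps the core of compound 1 and changes on an amide-type nitrogen, where cyclopropyl leaves: a group of 11 heavy atoms (9 carbon, 1 nitrogen, 1 oxygen; one six-membered non-aromatic ring with 1 hetero atom) in place of a group of 3 heavy atoms (3 carbon; one three-membered non-aromatic ring of carbon only), on an amide-type nitrogen. For the measured compounds named here, no measured step covers this change, so the expectation leans only on compound 2 , which gives a readable 23700 nM in this assay. The expected at least 4.0-fold lower number from compound 1 to compound 3 (0.60 log units; beyond the scatter) points toward stronger inhibition, of moderate size, and the result may still prove to be a limit. Compound 3 is estimated at 25000 nM, within an expected range of 4000 nM to 100000 nM.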

Compound 3, half-maximal inhibitory concentration: 41200 nM
Compound 3: middle estimate off by 1.6-fold (0.22 log units), on the low side, and the stated range covers the measured number.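

In this assay, the amide-type nitrogen on the core of compound 1 tolerates a six-membered non-aromatic ring group of 11 heavy atoms in place of cyclopropyl, and the change gives an at least 2.4-fold lower number from compound 1 to compound 3 (0.38 log units; beyond the scatter). The step is only a lower bound on the size of the change, since compound 1 gives a limit and not a number: the limit of > 100000 nM in this assay, at which 1 of the 3 values shown sits.

The compounds shown leave open whether a plain cyclohexyl group, with no ring nitrogen or attached oxygen, would give a similar number. They also leave open how an amine or a carboxylic acid at this place would read.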